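Propylsulfanyl in Place of Methoxy: Expecting Compound 4

The source may hold more compounds than are shown below. What is called first, only, known or untested is meant among the compounds shown, and "the series" means these compounds.

Three compounds sharing one core were tested in an in vitro functional assay on 1321-N1 cells for agonist activity at P2Y purinoceptor 6 (Homo sapiens), read by scintillation proximity assay and inositol phosphate accumulation; a lower number here means that less compound is needed, a higher number that more compound is needed for the effect. Compound 2 `COc1nc(=O)ccn1[C@@H]1O[C@H](COP(=O)(O)OP(=O)(O)O)[C@@H](O)[C@H]1O` gives 1370 nM. Compound 1 `CCCSc1nc(=O)ccn1[C@@H]1O[C@H](COP(=O)(O)OP(=O)(O)O)[C@@H](O)[C@H]1O` gives >= 100000 nM, which is a limit of this assay rather than a number. Compound 3 `COc1nc(=O)ccn1[C@@H]1O[C@H](COP(=O)(O)O)[C@@H](O)[C@H]1O` gives 9800 nM. The change from compound 2 to compound 1 is propylsulfanyl in place of methoxy on an aromatic carbon and it made a step of an at least 72-fold higher number from compound 2 to compound 1 (1.86 log units; beyond the scatter). From compound 2 to compound 3 the change is a hydrogen atom in place of a group of 4 heavy atoms (3 oxygen, 1 phosphorus; no ring), on an oxygen, giving a 7.2-fold higher number from compound 2 to compound 3 (0.85 log units; beyond the scatter). Compound 4 `CCCSc1nc(=O)ccn1[C@@H]1O[C@H](COP(=O)(O)O)[C@@H](O)[C@H]1O` has not yet been measured in this assay. It arises from compound 3 by propylsulfanyl in place of methoxy on an aromatic carbon, the same change as from compound 2 to compound 1, with the same surroundings around the place. For compound 4 a step of a 31-fold higher number from compound 3 to compound 4 (1.49 log units; beyond the scatter) in this assay is expected, resting on the step of an at least 72-fold higher number from compound 2 to compound 1 (1.86 log units; beyond the scatter) seen with the same change and on the limit of >= 100000 nM in this assay, at which 1 of the 3 values shown sits, where compound 1 sits. Compound 4 is therefore estimated at 300000 nM, most likely again reported only as a limit, with a range from 100000 nM to 1500000 nM.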

Compound 4, half-maximal effective concentration: 6200 nM
The estimate for compound 4 lay 48-fold (1.68 log units) above the measured number; measured number below the stated range.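

The new step is a 1.6-fold lower number from compound 3 to compound 4 (0.20 log units; within the scatter), so in this assay propylsulfanyl in place of methoxy does not repeat on the core of compound 3 what it did on the core of compound 2: the same change on two cores in this assay, an at least 72-fold higher number (1.86 log units; beyond the scatter) from compound 2 to compound 1 and a 1.6-fold lower number (0.20 log units; within the scatter) from compound 3 to compound 4, at least 110-fold (2.06 log units) apart, beyond the scatter of two such steps. Losing the group of 4 heavy atoms also depends on what sits on the aromatic carbon, as the propylsulfanyl pair shows an at least 16-fold lower number from compound 1 to compound 4 (1.20 log units; beyond the scatter): the same change on two cores in this assay, a 7.2-fold higher number (0.85 log units; beyond the scatter) from compound 2 to compound 3 and an at least 16-fold lower number (1.20 log units; beyond the scatter) from compound 1 to compound 4, at least 110-fold (2.06 log units) apart, beyond the scatter of two such steps. As far as these compounds go, compound 1 gives >= 100000 nM, which is a limit and not a number, so the true size of these gaps remains unknown, and two cores cannot show how the change would behave on any other core.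

The compounds shown hold only methoxy and propylsulfanyl on this aromatic carbon, so the sulfur and the longer chain always change together. A methylsulfanyl or a propoxy group there would separate the two, and an amine on the same carbon would test whether the difference between the cores extends to other groups.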